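The source may hold more compounds than are shown below. What is called first, only, known or untested is meant among the compounds shown, and "the series" means these compounds.

Of the compounds shown here, three have so far been tested in an ADME assay on BHK-21 cells (Mesocricetus auratus) for cytotoxicity, with a stated time of 3 days; on this read-out higher numbers stand for lower toxicity in this test and lower numbers for higher toxicity in this test. Compound 2 `CC(Sc1nnc(-c2ccncc2)s1)C(=O)Nc1ccc(Cl)cc1` reaches only a limit there, > 50000 nM. Compound 1 `CC(Sc1nnc(-c2ccncc2)s1)C(=O)Nc1c(Cl)cccc1Cl` likewise gives only a limit in this assay, > 50000 nM. Compound 3 `CC(CSc1nnc(-c2ccncc2)s1)C(=O)Nc1ccc(Cl)cc1` also stops at a limit in this assay, > 50000 nM. Compound 1 differs from compound 2 by 2,6-dichlorophenyl in place of 4-chlorophenyl on an amide-type nitrogen, and the step that the two limits leave unreadable from compound 2 to compound 1 cannot be read because of the limit of > 50000 nM in this assay, at which 3 of the 3 values shown sit. The difference between the cores of compound 2 and compound 3 is not broken down here. Compound 4 `CC(CSc1nnc(-c2ccncc2)s1)C(=O)Nc1c(Cl)cccc1Cl` has not yet been measured; it differs from compound 3 by 2,6-dichlorophenyl in place of 4-chlorophenyl on an amide-type nitrogen, the same change as from compound 2 to compound 1. The step that the limit leaves unreadable from compound 3 to compound 4 is expected to be small, since the same change left compound 1 at a limit, > 50000 nM. Compound 4 is therefore estimated at 80000 nM in this assay, with a range from 30000 nM to 250000 nM.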

Compound 4, half-maximal cytotoxic concentration: > 50000 nM
Compound 4 gave a limit, no number (the forecaster's own chance of this, stated with the estimate: 85%); the middle value lies beyond the limit too.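

No step can be read from compound 3 to compound 4 in this assay because both stop at a limit: the limit of > 50000 nM in this assay, at which 4 of the 4 values shown sit.

The compounds shown leave open whether 2,6-dichlorophenyl in place of 4-chlorophenyl changes the cytotoxic concentration at all.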